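Moving the fluorine from compound 2 to compound 3

A few compounds are considered here, and "the series" means these few. Any claim that something is new, unique, unknown or untested is made for them only; others in the source may bear on it.

In a functional assay on NCI-H460 cells (Homo sapiens) for cytotoxicity, read by MTT assay, with a stated time of 48 h (on this read-out higher numbers stand for weaker inhibition and lower numbers for stronger inhibition), compound 1 `COc1ccc2[nH]c(-c3ccccc3F)cc(=O)c2c1OC` gives > 20000 nM as a limit and not a number. Within the data shown here, compound 2 `COc1ccc2[nH]c(-c3cccc(F)c3)cc(=O)c2c1OC` reads 3500 nM and holds the only actual number so far. The change to compound 3 `COc1ccc2[nH]c(-c3ccc(F)cc3)cc(=O)c2c1OC` is 4-fluorophenyl in place of 3-fluorophenyl on an aromatic carbon with 4-fluorophenyl in place of 3-fluorophenyl. Among the measured compounds shown here, the one measured step bearing on this is an at least 5.7-fold lower number from compound 1 to compound 2 (0.75 log units; beyond the scatter) and its size rests on the limit of > 20000 nM in this assay, at which 1 of the 2 values shown sits, and so remains only a bound. With that single step to go on, the expected move is a 1.1-fold higher number from compound 2 to compound 3 (0.06 log units; within the scatter) and no change beyond the scatter is anticipated in either direction. Compound 3 is estimated at 4000 nM within a range from 1400 nM to 12000 nM for now.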

Compound 3, half-maximal inhibitory concentration: > 20000 nM
Compound 3 ended at the assay's limit; the forecaster's own chance of this, stated with the estimate: 12%; middle value at least 5.0-fold (0.69 log units) from the limit.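

In this assay the change to 4-fluorophenyl gives an at least 5.7-fold higher number from compound 2 to compound 3 (0.75 log units; beyond the scatter), so 3-fluorophenyl in compound 2 now stands apart from both other fluorophenyl groups, not only from 2-fluorophenyl. The reading of compound 3, > 20000 nM, is a limit and not a number. The step between compound 1 and compound 3 cannot be read because both readings are limits: the limit of > 20000 nM in this assay, at which 2 of the 3 values shown sit.

The compounds shown leave open whether 3-chlorophenyl, 3-methoxyphenyl or plain phenyl would keep a measurable number on this position.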